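Phenyl in Place of Isopropyl: Expected Solubility Shift

The source may hold more compounds than are shown below. What is called first, only, known or untested is meant among the compounds shown, and "the series" means these compounds.

Measured so far:
Compound 1 `C=CC(=O)N1CCC[C@@H](N2C(=O)N(Cc3ccccc3)Cc3cnc(Nc4ccc(N5CCN(C)CC5)cc4OC)nc32)C1` gives 142 ug/mL in a physicochemical assay for solubility, read by HPLC, in phosphate buffer, measured as thermodynamic solubility, with a stated time of 24 h, at pH 6.8; on this read-out lower numbers stand for lower solubility and higher numbers for higher solubility.
Compound 2 `C=CC(=O)N1CC[C@H](N2C(=O)N(C(C)C)Cc3cnc(Nc4ccc(N5CCN(C)CC5)cc4OC)nc32)C1` gives 2490 ug/mL in this assay.

Compound 2 stands highest of the two numbers; its nearest neighbour, compound 1, lies lower, with a gap beyond the usual scatter. Compound 3 `C=CC(=O)N1CC[C@H](N2C(=O)N(c3ccccc3)Cc3cnc(Nc4ccc(N5CCN(C)CC5)cc4OC)nc32)C1` has not yet been measured. It differs from compound 2 by phenyl in place of isopropyl on an amide-type nitrogen in a ring. For the measured compounds named here, no comparable step between measured compounds exists here, so the direction rests on expectation alone. A drop beyond the scatter is expected in this assay, the step of a 7.1-fold lower number from compound 2 to compound 3 (0.85 log units; beyond the scatter). Compound 3 is estimated at 350 ug/mL, within 80 ug/mL to 1400 ug/mL.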

Compound 3, solubility: 1540 ug/mL
Compound 3: the middle estimate sits 4.4-fold (0.64 log units) below what was measured; the whole stated range lies below it.
By their numbers in this assay, from the lowest: compound 1; then compounds 3 and 2 (each within the scatter of the next).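

On the amide-type nitrogen in a ring, phenyl in place of isopropyl gives a 1.6-fold lower number from compound 2 to compound 3 (0.21 log units; within the scatter) in this assay, the first step shown that changes this position alone. A six-membered aromatic ring of carbon only can therefore stand here without a shift that can be told from the scatter. Nothing shown explains this outcome. Still open, as far as these compounds go, is whether an amine, a carboxylic acid or a longer chain on this nitrogen would also stay within the scatter of compound 2 in this assay.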